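The source may report more compounds than this note shows. Statements on the series, on what has been measured and on what is new or still open speak of the compounds shown alone.

Compound 1 `Cc1ccc(NC(=O)c2cccc(/C=C3\CC(=O)N(c4ccccc4)C3=O)c2)cc1C` in an ADME assay on HCT-116 cells (Homo sapiens) for cytotoxicity, read by MTT assay, with a stated time of 72 h; on this read-out higher numbers stand for weaker inhibition and lower numbers for stronger inhibition: > 100000 nM
Compound 2 `CCOc1ccc(NC(=O)c2cccc(/C=C3\CC(=O)N(Cc4ccccc4)C3=O)c2)cc1`: 41700 nM

Compound 1 reaches only the limit of this assay, > 100000 nM, so its standing is known as a bound and not as a number (the limit of > 100000 nM in this assay, at which 1 of the 2 values shown sits). Compound 2 gives 41700 nM in this assay. Compound 3 `CSc1cccc(NC(=O)c2cccc(/C=C3\CC(=O)N(c4ccccc4)C3=O)c2)c1` differs from compound 1 by 3-(methylsulfanyl)phenyl in place of 3,4-dimethylphenyl on an amide-type nitrogen. Among the compounds with values here, no step between measured compounds is available; since compound 1 sits at a limit, a step from compound 1 to compound 3 of no more than the usual scatter is expected, in either direction. Compound 3 is expected to give 100000 nM, between 30000 nM and 300000 nM, an expected step of a number no higher from compound 1 to compound 3 (the limit leaves the size open).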

Compound 3, half-maximal inhibitory concentration: 65200 nM
Estimate against measurement, compound 3: 1.5-fold (0.19 log units) above, within the range that was stated.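

In this assay, 3-(methylsulfanyl)phenyl in place of 3,4-dimethylphenyl on the amide-type nitrogen gives an at least 1.5-fold lower number from compound 1 to compound 3 (0.18 log units; that floor lies within the scatter). Within the data shown here, this gives the first step at this position, and compound 3 gives the first actual number for the shared core, so a sulfur-bearing group here still yields a reading inside the assay's range. Compound 1 stands only at a limit, so the full size of the step cannot be read: the limit of > 100000 nM in this assay, at which 1 of the 3 values shown sits.

Going by these compounds, whether the step truly exceeds the scatter remains open. So does how an amine, a carboxylic acid or a longer chain at this position would read.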